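The source may report more compounds than this note shows. Statements on the series, on what has been measured and on what is new or still open speak of the compounds shown alone.

Compound 1 `COc1cc(-c2nc3cc(C(F)(F)F)ccc3[nH]2)cc(OC)c1OC`: 31000 nM
Compound 2 `COc1ccc(-c2nc3cc(Cl)c(Cl)cc3[nH]2)c([N+](=O)[O-])c1`: 80000 nM
Compound 3 `O=[N+]([O-])c1ccc(-c2nc3cc(Cl)c(Cl)cc3[nH]2)cc1`: > 100000 nM

All three values come from an ADME assay on BHK cells (Mesocricetus auratus) for cytotoxicity, read by MTT assay, with a stated time of 96 h; a higher number here means that more compound is tolerated, a lower number that less compound is tolerated. Compound 3 stands at > 100000 nM, which is a limit of the assay and not a number. Compound 4 `Nc1ccc(-c2nc3cc(Cl)c(Cl)cc3[nH]2)cc1` has not yet been measured. It carries amino in place of nitro on an aromatic carbon, para to a large group: amino in place of nitro on an aromatic carbon. For the measured compounds named here, no measured pair isolates this swap, so any expectation is loose. Compound 2 gives 80000 nM and compound 1 gives 31000 nM, so real numbers do occur in this set, and a moderate fall is expected. The expected change is an at least 2.0-fold lower number from compound 3 to compound 4 (0.30 log units; that floor lies within the scatter), towards less compound tolerated. For compound 4 the estimate is 50000 nM, with an expected range from 15000 nM to 100000 nM.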

Compound 4, half-maximal cytotoxic concentration: 30000 nM
For compound 4 the middle estimate is 1.7-fold (0.22 log units) above the measured one; measured number inside the range.
By their numbers in this assay, from the lowest: compounds 4 and 1 (each within the scatter of the next); then compound 2. At a limit, above all of these: compound 3.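

Amino in place of nitro on this aromatic carbon, para to a large group, is the one single change that can be read here: in this assay it gives an at least 3.3-fold lower number from compound 3 to compound 4 (0.52 log units; beyond the scatter) with nothing else in the molecule altered. So what sits at this position matters for how much compound the cells tolerate. Only a floor can be given for this step because compound 3 sits at a limit of the assay and not at a number: the limit of > 100000 nM in this assay, at which 1 of the 4 values shown sits.

The compounds shown leave open where other groups at this position, such as a hydroxyl or a carboxylic acid, would fall. They also leave open whether the same swap would act alike on the core of compound 1.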